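The compounds below may be only part of what the source reports. "The series", "measured", "known", "first", "only" and "open" are said of these compounds alone.

Three compounds share one core. Compound 1 `Brc1ccc2ccn(CCN3CCN4CCCCC4C3)c2c1` gives 70 nM in an assay on HEK293 cells for binding affinity to 5-hydroxytryptamine receptor 7 (Homo sapiens), read by radioligand binding (a higher number here means a weaker inhibitor, a lower number a stronger inhibitor), compound 2 `CN1CCCN(CCn2ccc3ccc(Cl)cc32)CC1` gives 34 nM, and compound 3 `C=Cc1ccc2ccn(CCN3CCCN(C)CC3)c2c1` gives 109 nM. Compound 3 thus carries the highest of the three numbers, lying within the scatter of compound 1 but beyond it relative to compound 2. Within the data shown here, the single measured change at this position is the step of a 3.2-fold higher number from compound 2 to compound 3 (0.51 log units; beyond the scatter). Compound 4 `CN1CCCN(CCn2ccc3ccc(-c4ccsc4)cc32)CC1` differs from compound 3 by thiophen-3-yl in place of vinyl on an aromatic carbon. Among the measured compounds shown here, no measured step exchanges vinyl for an aromatic ring, so only that modest chloro-to-vinyl shift offers any guide, and its direction need not carry over. For compound 4 a step of a 1.4-fold lower number from compound 3 to compound 4 (0.13 log units; within the scatter) is therefore expected, giving an estimate of 80 nM with a range from 25 nM to 250 nM.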

Compound 4, inhibition constant: 109 nM
Beside the measured number, compound 4's estimate is 1.4-fold (0.13 log units) below it, within the range that was stated.
By their numbers in this assay, from the lowest: compound 2; then compounds 1, 3 and 4 (each within the scatter of the next).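

Exchanging vinyl for thiophen-3-yl on this aromatic carbon gives no change at the digits printed from compound 3 to compound 4 (within the scatter) in this assay, so this position accepts a five-membered aromatic ring with no difference from a group of two carbons. Set against chloro, the same ring gives a 3.2-fold higher number from compound 2 to compound 4 (0.51 log units; beyond the scatter), a step that matches a 3.2-fold higher number from compound 2 to compound 3 (0.51 log units; beyond the scatter) in size. Nothing on hand offers a reason for either step. Going by these compounds, what an amine or a carboxylic acid on this carbon would give remains open, as does whether thiophen-3-yl would behave alike with the side chain of compound 1.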